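A Dimethoxyphenyl Variant of a Glycosylated Oxindole Triazole

This account rests on a few compounds, and the source may have more. Where it says the series, first, only, none or still open, it means among the compounds named here.

The three measured compounds were tested in a functional assay on DU-145 cells (Homo sapiens) for cytotoxicity, read by sulforhodamine B assay, with a stated time of 48 h; a higher number here means a weaker inhibitor, a lower number a stronger inhibitor. Compound 1 `CC(=O)OC[C@H]1O[C@@H](n2cc(Cn3cc([N+](=O)[O-])c4ccccc43)nn2)[C@H](OC(C)=O)[C@@H](OC(C)=O)[C@@H]1OC(C)=O` gives 60900 nM in this assay. Compound 2 `CC(=O)OC[C@H]1O[C@@H](n2cc(CN3C(=O)/C(=C\c4ccccc4)c4ccccc43)nn2)[C@H](OC(C)=O)[C@@H](OC(C)=O)[C@@H]1OC(C)=O` gives 24100 nM, and compound 3 `CC(=O)OC[C@H]1O[C@@H](n2cc(CN3C(=O)/C(=C/c4ccccc4)c4ccccc43)nn2)[C@H](OC(C)=O)[C@@H](OC(C)=O)[C@@H]1OC(C)=O` gives 22800 nM. Compound 2 therefore stands second highest of the three numbers: the step of a 1.1-fold lower number from compound 2 to compound 3 (0.02 log units; within the scatter) lies within the scatter, the pair being characterised by the fact that compounds 2 and 3 differ only in the configuration as drawn, while the number for compound 1 sits beyond the scatter above compound 2.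

Compound 4 `COc1ccc(/C=C2\C(=O)N(Cc3cn([C@@H]4O[C@H](COC(C)=O)[C@@H](OC(C)=O)[C@H](OC(C)=O)[C@H]4OC(C)=O)nn3)c3ccccc32)cc1OC` has not yet been measured. It differs from compound 2 by 3,4-dimethoxyphenyl in place of phenyl on a double-bonded chain carbon bound to a double-bonded ring carbon. Going by the values given here, no measured pair exchanges the group on that chain carbon, so the only step touching this part of the molecule is the configurational one between compound 2 and compound 3, which stayed within the scatter. The data thus give no basis for expecting a shift beyond the scatter in this assay, and the step of a 1.2-fold lower number from compound 2 to compound 4 (0.08 log units; within the scatter) is expected to be small in either direction. Compound 4 is estimated at 20000 nM, with a range from 7000 nM to 60000 nM.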

Compound 4, half-maximal inhibitory concentration: 24900 nM
Estimate against measurement, compound 4: 1.2-fold (0.10 log units) below; low and high end bracket the measured number.
By their numbers in this assay, from the lowest: compounds 3, 2 and 4 (each within the scatter of the next); then compound 1.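

In this assay, going by these compounds alone, the step of a 1.0-fold higher number from compound 2 to compound 4 (0.01 log units; within the scatter) is the only measured exchange of the group on a double-bonded chain carbon bound to a double-bonded ring carbon. The earlier compounds shown here varied only the configuration drawn at that double bond, whereas here 3,4-dimethoxyphenyl replaces phenyl, bringing more heavy atoms and hydrogen-bond acceptors that phenyl lacks, and still no difference beyond the scatter appears. Nothing given here accounts for this result.

The compounds shown leave open whether 3,4-dimethoxyphenyl would give a comparable number with the double bond in the other configuration. They also leave open whether a different group at this place, such as an amine or a carboxylic acid on the phenyl ring, would shift the number beyond the scatter.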